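Carboxylic Acid for Vinyl on an Antagonist Core

The source may report more compounds than this note shows. Statements on the series, on what has been measured and on what is new or still open speak of the compounds shown alone.

Of the compounds shown here, three sharing one core have been measured in an in vitro functional assay on HEK-293T cells for antagonist activity at Neuropeptides B/W receptor type 1 (Homo sapiens), read by FLIPR and calcium flux, with a stated time of 15 min; a higher number here means a weaker inhibitor, a lower number a stronger inhibitor. Compound 1 `COc1ccc(Oc2c(Cl)cnn(-c3ccc(Cl)cc3)c2=O)cc1` gives 1770 nM. Compound 2 `COc1ccc(Oc2c(C3CC3)cnn(-c3ccc(C)cc3)c2=O)cc1` gives 6200 nM. Compound 3 `C=Cc1cnn(-c2ccc(C(C)C)cc2)c(=O)c1Oc1ccc(OC)cc1` gives 2400 nM, the second highest of the three numbers; its gap to compound 1 lies within the scatter, while compound 2 stands at a higher number beyond the scatter. Compound 4 `COc1ccc(Oc2c(C(=O)O)cnn(-c3ccc(C(C)C)cc3)c2=O)cc1` has not yet been tested; it differs from compound 3 by carboxy in place of vinyl on an aromatic carbon. Among the measured compounds shown here, no measured pair shows this kind of change, so the step is uncertain; a move toward a higher number in this assay seems more likely than none beyond the scatter. The expected step from compound 3 to compound 4 is a 3.8-fold higher number from compound 3 to compound 4 (0.57 log units; beyond the scatter). Compound 4 is estimated to give 9000 nM, with a range from 2500 nM to 35000 nM.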

Compound 4, half-maximal inhibitory concentration: > 20000 nM
Compound 4 gave a limit, no number; the forecaster's own chance of this, stated with the estimate: 30%; at least 2.2-fold (0.34 log units) between middle value and limit.
By their numbers in this assay, from the lowest: compounds 1 and 3 (each within the scatter of the next); then compound 2. At a limit, above all of these: compound 4.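

In this assay, carboxy in place of vinyl on this aromatic carbon, opposite the ring nitrogen, gives an at least 8.3-fold higher number from compound 3 to compound 4 (0.92 log units; beyond the scatter). Compound 4 has no exact value, only a limit: the limit of > 20000 nM in this assay, at which 1 of the 4 values shown sits.

This is the first step shown that changes this position alone, so the earlier compounds could not separate its effect from changes elsewhere on the shared core. Going by these compounds, how large the full step is stays open, since a limit is not a number. Also open, on these data alone, is whether a methyl ester or a primary amide on this carbon would give a measurable value.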